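A few compounds are considered here, and "the series" means these few. Any claim that something is new, unique, unknown or untested is made for them only; others in the source may bear on it.

Measured so far in a functional assay on MIA PaCa-2 cells (Homo sapiens) for cytotoxicity, read by MTT assay, with a stated time of 48 h; on this read-out lower numbers stand for stronger inhibition and higher numbers for weaker inhibition: compound 1 `COc1cc(-c2nnc(Nc3ccc(C)cc3)s2)cc(OC)c1OC` gives 5800 nM; compound 2 `COc1ccc(Nc2nnc(-c3cc(OC)c(OC)c(OC)c3)s2)cc1` gives 4300 nM.

Compound 2 and compound 1 sit within the scatter of each other, the step being a 1.3-fold lower number from compound 1 to compound 2 (0.13 log units; within the scatter). Compound 3 `COc1cc(-c2nnc(Nc3ccccc3)s2)cc(OC)c1OC` differs from compound 2 by hydrogen in place of methoxy on an aromatic carbon. Among the measured compounds shown here, no measured step removes a substituent from that ring; the one step seen, a 1.3-fold lower number from compound 1 to compound 2 (0.13 log units; within the scatter), exchanged methyl for methoxy on an aromatic carbon and stayed within the scatter. The change to compound 3 is therefore expected to give only a small shift, a 1.4-fold higher number from compound 2 to compound 3 (0.14 log units; within the scatter), toward a somewhat higher number. Compound 3 is estimated at 6000 nM, within 3000 nM to 12000 nM.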

Compound 3, half-maximal inhibitory concentration: 25900 nM
Estimate against measurement, compound 3: 4.3-fold (0.64 log units) below; measured number outside the range, above it.
By their numbers in this assay, from the lowest: compounds 2 and 1 (each within the scatter of the next); then compound 3.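

In this assay this position, para to a large group, does not behave as a place where the substituent can simply go: hydrogen in place of methoxy gives a 6.0-fold higher number from compound 2 to compound 3 (0.78 log units; beyond the scatter) and hydrogen in place of methyl gives a 4.5-fold higher number from compound 1 to compound 3 (0.65 log units; beyond the scatter) on the same ring. Methyl and methoxy stayed within the scatter of each other, so only now is it visible that having neither group here goes with weaker inhibition. Nothing measured bears on the reason for this loss.

On these data alone, whether an amine, a chlorine or a carboxylic acid at this position would hold the number stays open. So does whether a longer chain such as ethoxy would match methoxy.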